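This account rests on a few compounds, and the source may have more. Where it says the series, first, only, none or still open, it means among the compounds named here.

Working notes on the series, cytotoxicity arm.

Compound 3 `CCCCCc1ccc(C#Cc2cn(C/C=C\CN3C(=O)c4ccccc4C3=O)c(=O)[nH]c2=O)cc1` is tested in an ADME assay on WI-38 cells (Homo sapiens) for cytotoxicity, read by MTT assay, with a stated time of 3 days; on this read-out higher numbers stand for weaker inhibition and lower numbers for stronger inhibition. In this assay compound 3 gives > 100000 nM, which is a limit of the assay and not a number. Compound 1 `Cc1ccc(C#Cc2cn(C/C=C\CN3C(=O)c4ccccc4C3=O)c(=O)[nH]c2=O)cc1` shares that position: in this assay compound 1 gives > 100000 nM, again a limit. Within the data shown here, compound 2 `CCCCCCCCC#Cc1cn(C/C=C\CN2C(=O)c3ccccc3C2=O)c(=O)[nH]c1=O` is the only member with a number; in this assay compound 2 gives 49000 nM. Two of the three values therefore sit at the limit of > 100000 nM in this assay, at which 2 of the 3 values shown sit.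

Compound 4 `CCCCC#Cc1cn(C/C=C\CN2C(=O)c3ccccc3C2=O)c(=O)[nH]c1=O` differs from compound 3 in one place: butyl in place of 4-pentylphenyl on a triple-bonded carbon. Among the measured compounds shown here, two measured steps bear on this. Going from compound 1 to compound 2, octyl in place of 4-methylphenyl on a triple-bonded carbon, the step was an at least 2.0-fold lower number from compound 1 to compound 2 (0.30 log units; that floor lies within the scatter). The reverse kind of swap, 4-pentylphenyl in place of octyl, gave an at least 2.0-fold higher number from compound 2 to compound 3 (0.30 log units; that floor lies within the scatter). Both carry an aryl-to-chain or chain-to-aryl change, and both are floored by the limit, so their true size is not readable.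

For compound 4 a step of an at least 1.6-fold lower number from compound 3 to compound 4 (0.22 log units; that floor lies within the scatter) is expected, in line with compound 2 at 49000 nM. Compound 4 is estimated at 60000 nM, range 25000 nM to 150000 nM.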

Compound 4, half-maximal inhibitory concentration: 28000 nM
For compound 4 the middle estimate is 2.1-fold (0.33 log units) above the measured one, within the range that was stated.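

In this assay this position now shows steps beyond the scatter: butyl in place of 4-pentylphenyl on the triple-bonded carbon gives an at least 3.5-fold lower number from compound 3 to compound 4 (0.55 log units; beyond the scatter), and butyl in place of 4-methylphenyl gives an at least 3.5-fold lower number from compound 1 to compound 4 (0.55 log units; beyond the scatter). Between the two straight chains at this position, octyl and butyl, the change gives a 1.8-fold lower number from compound 2 to compound 4 (0.24 log units; within the scatter), so the four compounds divide by the kind of group on this carbon and not by the length of the chain. Both steps beyond the scatter remain floors because the two compounds carrying a phenyl group stand at a limit: the limit of > 100000 nM in this assay, at which 2 of the 4 values shown sit.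

The true size of those steps and the step between compound 1 and compound 3 cannot be read. On these data alone, whether a chain ending in an amine or a carboxylic acid, or a propyl chain, would follow butyl and octyl at this position remains open.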